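This account rests on a few compounds, and the source may have more. Where it says the series, first, only, none or still open, it means among the compounds named here.

Compound 1 `O=C(CSc1nnc(-c2ccncc2)o1)N/N=C/c1ccccc1` is the parent of this small set. In a functional assay on BGC-823 cells (Homo sapiens) for cytotoxicity, read by MTT assay, with a stated time of 48 h (a higher number here means a weaker inhibitor, a lower number a stronger inhibitor), compound 1 gives 22100 nM, the highest number of the three. Compound 2 `COc1cccc(/C=N/NC(=O)CSc2nnc(-c3ccncc3)o2)c1` gives 15800 nM, and compound 3 `O=C(CSc1nnc(-c2ccncc2)o1)N/N=C/c1cc(Cl)ccc1O` gives 5470 nM. The step of a 1.4-fold lower number from compound 1 to compound 2 (0.15 log units; within the scatter) changes little, whereas a 4.0-fold lower number from compound 1 to compound 3 (0.61 log units; beyond the scatter) and a 2.9-fold lower number from compound 2 to compound 3 (0.46 log units; beyond the scatter) are modest but clear. Compound 4 `O=C(CSc1nnc(-c2ccncc2)o1)N/N=C/c1cc(Cl)cc(Cl)c1O` has not yet been measured; it differs from compound 1 in one place: 3,5-dichloro-2-hydroxyphenyl in place of phenyl on a carbon with a double bond to nitrogen. The step from compound 1 to compound 3 is the closest guide, as compound 3 already carries one chlorine and the hydroxyl. A lower number in this assay is therefore expected for compound 4, about a 5.5-fold lower number from compound 1 to compound 4 (0.74 log units; beyond the scatter). Compound 4 is estimated at 4000 nM, with a likely range from 1500 nM to 11000 nM.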

Compound 4, half-maximal inhibitory concentration: 6340 nM
The estimate for compound 4 lay 1.6-fold (0.20 log units) below the measured number, and the stated range covers the measured number.
By their numbers in this assay, from the lowest: compounds 3 and 4 (each within the scatter of the next); then compounds 2 and 1 (each within the scatter of the next).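

A second chlorine on the ring makes no difference beyond the scatter, with a 1.2-fold higher number from compound 3 to compound 4 (0.06 log units; within the scatter) and so no clear separation between the two chlorinated compounds. The 3,5-dichloro-2-hydroxyphenyl group still keeps a modest advantage, with a 3.5-fold lower number from compound 1 to compound 4 (0.54 log units; beyond the scatter) and a 2.5-fold lower number from compound 2 to compound 4 (0.40 log units; beyond the scatter) as its two steps. No measurement available here explains this flat step. The compounds shown leave open whether the hydroxyl or the first chlorine carries the advantage, as neither stands alone on the ring. As far as these compounds go, whether an amine or a carboxylic acid in place of the hydroxyl would retain it also remains open.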